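Swapping a Hydroxy Group for Hydrogen on Compound 1

The compounds below may be only part of what the source reports. "The series", "measured", "known", "first", "only" and "open" are said of these compounds alone.

Within the data shown here, in a functional assay on A549 cells (Homo sapiens) for inhibition, read by sulforhodamine B assay, with a stated time of 48 h (on this read-out lower numbers stand for stronger inhibition of growth and higher numbers for weaker inhibition of growth), compound 1 `Cc1ccn2c(CN3CCCC3)c(-c3ccc(O)cc3)nc2n1` gives 2480 nM and holds the lower of the two numbers so far. Compound 2 `Cc1ccn2c(CN3CCCCC3)c(C(C)(C)C)nc2n1` gives 7390 nM in this assay as well, a gap beyond the usual scatter, but these two compounds differ in more than one place, so the gap cannot be pinned on any single group.

Compound 3 `Cc1ccn2c(CN3CCCC3)c(-c3ccccc3)nc2n1` has not been measured yet. It keeps the core of compound 1 and carries hydrogen in place of hydroxy on an aromatic carbon so that 4-hydroxyphenyl becomes phenyl. Among the measured compounds shown here, only one group changes in this comparison. Everything else stays the same. For the measured compounds named here, no measured pair shows this change on its own, so the only anchor is compound 1 at 2480 nM and the forecast is loose. A small step toward weaker inhibition of growth is expected, with a 1.4-fold higher number from compound 1 to compound 3 (0.15 log units; within the scatter) as the estimate and no move beyond the usual scatter. In this assay the estimated value for compound 3 is 3500 nM with a range that runs from 1300 nM to 9500 nM on repeated measurement.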

Compound 3, concentration for 50% growth inhibition: 4150 nM
Compound 3: middle estimate off by 1.2-fold (0.07 log units), on the low side; the measured number falls inside the stated range.
By their numbers in this assay, from the lowest: compounds 1, 3 and 2 (each within the scatter of the next, the first and the last beyond it).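

Among these compounds, this is the first comparison here in which only one place differs, so it can speak to the hydroxy group itself. In this assay, putting hydrogen in place of hydroxy on the aromatic carbon para to a large group gives a 1.7-fold higher number from compound 1 to compound 3 (0.22 log units; within the scatter) and leaves the two compounds indistinguishable on this read-out. At this position and in this setting, therefore, 4-hydroxyphenyl and phenyl cannot be told apart, and the hydroxy group shows no measurable contribution to inhibition of growth; no supporting data are available to explain this result.

As far as these compounds go, the pair tests only hydroxy against hydrogen, so it remains open whether a methoxy group, a fluorine atom, an amine or a carboxylic acid at this same place would move the number beyond the scatter. From the compounds shown here alone, it also remains open whether the same swap would give a similar result on a compound that differs elsewhere, since this single step comes from one pair that shares the core of compound 1.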